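Coumarin-isoxazole ethers and cell growth inhibition

The source may hold more compounds than are shown below. What is called first, only, known or untested is meant among the compounds shown, and "the series" means these compounds.

Measured compounds:
compound 1 `O=c1ccc2cc(OCc3cc(-c4ccccc4Cl)no3)ccc2o1` – "not determined" (no result reported)
compound 2 `O=c1ccc2cc(OCc3cc(-c4cccc5ccccc45)no3)ccc2o1` – 51500 nM

Two compounds of this series have been through a functional assay on HCT-116 cells (Homo sapiens) for cytotoxicity, read by MTT assay, with a stated time of 48 h; a higher number here means a weaker inhibitor, a lower number a stronger inhibitor. For compound 1 there is no number: the assay result is recorded as "not determined" (no result reported), so compound 1 cannot be placed on the scale. Compound 2 `O=c1ccc2cc(OCc3cc(-c4cccc5ccccc45)no3)ccc2o1`, which carries a naphthyl group on the shared core, gives 51500 nM in this assay, a weak effect on the cells.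

Compound 3 `O=c1ccc2cc(OCc3cc(-c4cccc([N+](=O)[O-])c4)no3)ccc2o1` is the next compound to be tested. It differs from compound 1 in one place: 3-nitrophenyl in place of 2-chlorophenyl on an aromatic carbon. Among the compounds with values here, no measured pair shows what such a change does in this assay, and compound 1 itself has no value, so the only anchor is compound 2. With that weak reading as the sole point of reference, compound 3 is expected to land in a similarly weak region rather than to become a strong inhibitor. The estimate for compound 3 in this assay is 35000 nM, with a range from 8000 nM to 150000 nM.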

Compound 3, half-maximal inhibitory concentration: 48200 nM
Compound 3: middle estimate off by 1.4-fold (0.14 log units), on the low side, within the range that was stated.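

Compound 3 gives 48200 nM in this assay, but compound 1 has no number there, and the change between compound 1 and compound 3 cannot be read as a step. The compounds shown leave open what going from 2-chlorophenyl to 3-nitrophenyl on the shared core does to the effect on these cells. Nothing shown here bears on the reading for compound 3.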